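This account rests on a few compounds, and the source may have more. Where it says the series, first, only, none or still open, it means among the compounds named here.

Compound 1 `O=C(O)CC/C=C\CC1COC(c2ccc([N+](=O)[O-])cc2)OC1c1cccnc1`: 39 nM in an assay for inhibition of Thromboxane-A synthase (Homo sapiens), using microsomes; on this read-out lower numbers stand for stronger inhibition and higher numbers for weaker inhibition
Compound 2 `O=C(O)CC/C=C\CC1COC(c2cccc3ccccc23)OC1c1cccnc1`: 40 nM
Compound 3 `CC(C)(Oc1ccccc1)C1OCC(C/C=C\CCC(=O)O)C(c2cccnc2)O1`: 52 nM

Compound 3 carries the highest number of the three, yet both a 1.3-fold higher number from compound 1 to compound 3 (0.12 log units; within the scatter) and a 1.3-fold higher number from compound 2 to compound 3 (0.11 log units; within the scatter) lie within the scatter, so the three compounds cannot be told apart on this read-out. Compound 4 `CC(C)(Oc1ccccc1O)C1OCC(C/C=C\CCC(=O)O)C(c2cccnc2)O1` follows from compound 3 by hydroxy in place of hydrogen on an aromatic carbon, so that phenoxy becomes 2-hydroxyphenoxy. For the measured compounds named here, no measured step adds a hydroxy to an aromatic carbon; the steps known all exchange the whole group on the saturated ring carbon, and those, with a 1.0-fold higher number from compound 1 to compound 2 (0.01 log units; within the scatter), stay within the scatter. A change this small at the edge of that group is therefore expected to give no step beyond the scatter: a 1.0-fold lower number from compound 3 to compound 4 (0.02 log units; within the scatter). Compound 4 is accordingly estimated at 50 nM, between 22 nM and 115 nM.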

Compound 4, half-maximal inhibitory concentration: 32 nM
Beside the measured number, compound 4's estimate is 1.6-fold (0.19 log units) above it; low and high end bracket the measured number.
By their numbers in this assay, from the lowest: compounds 4, 1, 2 and 3 (each within the scatter of the next).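

Hydroxy in place of hydrogen on an aromatic carbon, ortho to a large group, gives a 1.6-fold lower number from compound 3 to compound 4 (0.21 log units; within the scatter) in this assay and so leaves 2-hydroxyphenoxy indistinguishable from phenoxy on this read-out. The earlier steps shown here exchanged the whole group on the saturated ring carbon, whereas this one shows that a change at the edge of that group also stays within the scatter. No available evidence bears on this result.

The compounds shown leave open whether an amine or a methoxy group on the same aromatic carbon would also stay within the scatter.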